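Series notes: aryl change on the amide-type nitrogen

A few compounds are considered here, and "the series" means these few. Any claim that something is new, unique, unknown or untested is made for them only; others in the source may bear on it.

Measured so far:
compound 1 `COc1cc(NC(=O)Nc2cc(Nc3ccc(C(C)(C)C)cc3)ncn2)cc(OC)c1` — 32.7%
compound 2 `COc1cc(NC(=O)Nc2cc(Nc3ccc(C)c(C)c3)ncn2)cc(OC)c1` — 45.7%

In a functional assay on HCC827 cells (Homo sapiens) for inhibition, read by MTT assay, with a stated time of 48 h, tested at 10 uM (on this read-out higher numbers stand for more inhibition at the one concentration tested (going by the name of the read-out) and lower numbers for less inhibition), compound 1 gives 32.7%, the lowest of the two numbers measured. Its nearest neighbour is compound 2, which in this assay gives 45.7%; that step, a number 13 percentage points higher from compound 1 to compound 2 (beyond the scatter), is beyond the scatter and touches only the group on the nitrogen on the aromatic ring.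

Compound 3 `CC(C)(C)c1ccc(Nc2cc(NC(=O)Nc3c(Cl)cccc3Cl)ncn2)cc1` is not yet measured. It differs from compound 1 at another place: 2,6-dichlorophenyl in place of 3,5-dimethoxyphenyl on an amide-type nitrogen. Among the measured compounds shown here, no measured step bears on this site; the one step known concerns a different part of the shared core, so it gives no direction for compound 3. Absent any relevant step, no change beyond the scatter is expected in this assay from compound 1 to compound 3, and the estimated step is a number 2.3 percentage points higher from compound 1 to compound 3 (within the scatter). The expected value for compound 3 is 35%, within a range from 15% to 55%.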

Compound 3, a percentage reported as inhibition, at one concentration (the size of the read-out at that concentration, not a potency): 42.3%
Estimate against measurement, compound 3: 7.3 percentage points below; the measured number falls inside the stated range.
By their numbers in this assay, from the lowest: compounds 1, 3 and 2 (each within the scatter of the next, the first and the last beyond it).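

In this assay, among the compounds shown here, 2,6-dichlorophenyl in place of 3,5-dimethoxyphenyl on the amide-type nitrogen gives a number 9.6 percentage points higher from compound 1 to compound 3 (within the scatter), the first reading at this site. With 4-(tert-butyl)phenyl held constant, this one exchange of aryl groups does not separate compound 3 from compound 1, even though the two methoxy groups are replaced by two chlorines. No measurement on hand offers an explanation for this result.

The compounds shown leave open how a plain phenyl, a pyridine ring or a cyclohexyl group on the amide-type nitrogen would read. Also open, going by these compounds, is whether 2,6-dichlorophenyl at this site would read the same with 3,4-dimethylphenyl in place of 4-(tert-butyl)phenyl.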